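Swapping Nitro for Chloro on a Shared Core

The source may hold more compounds than are shown below. What is called first, only, known or untested is meant among the compounds shown, and "the series" means these compounds.

Measured in a functional assay on the whole organism (stomach) for inhibition, with Rattus norvegicus as the target; a lower number here means that less compound is needed, a higher number that more compound is needed for the effect:
compound 1 `O=C(O)CCC/C=C1\CC2C[C@@H](O)[C@H](/C=C/[C@@H](O)c3ccc4c(c3)OCCO4)C2C1`: > 0.3 mg/kg (a limit)
compound 2 `O=C(O)CCC/C=C1\CC2C[C@@H](O)[C@H](/C=C/[C@@H](O)C3Cc4ccc([N+](=O)[O-])cc4C3)C2C1`: 0.14 mg/kg

The entry for compound 1 is a limit and not a number. For the measured compounds named here, compound 2, at 0.14 mg/kg, holds the only exact value in this assay. Compound 3 `O=C(O)CCC/C=C1\CC2C[C@@H](O)[C@H](/C=C/[C@@H](O)C3Cc4ccc(Cl)cc4C3)C2C1` has chloro in place of nitro on an aromatic carbon, on a six-membered aromatic ring of carbon only (chloro in place of nitro on an aromatic carbon). Going by the values given here, no measured pair shows what this exchange does, so no change beyond the scatter is expected. The estimated step of a 1.1-fold higher number from compound 2 to compound 3 (0.03 log units; within the scatter) is correspondingly small. For compound 3 the estimate is 0.15 mg/kg, with an expected range of 0.04 mg/kg to 0.5 mg/kg.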

Compound 3, dose for half-maximal effect: > 0.3 mg/kg
Compound 3 was reported as a limit; the forecaster's own chance of this, stated with the estimate: 15%; middle value at least 2.0-fold (0.30 log units) away from the limit.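

In this assay, for the compounds shown here, chloro in place of nitro on this aromatic carbon gives an at least 2.1-fold higher number from compound 2 to compound 3 (0.33 log units; beyond the scatter), the first step that can be read. The exchange therefore matters at this position, with the nitro compound needing less compound for the effect. The entry for compound 3, > 0.3 mg/kg, is a limit and not a number.

As far as these compounds go, the full size of this step stays open, and the step between the two limits of compound 1 and compound 3 cannot be read. Also open, from the compounds shown here alone, is how a nitrile or an amine on this carbon would compare with nitro.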